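This account rests on a few compounds, and the source may have more. Where it says the series, first, only, none or still open, it means among the compounds named here.

Working notes on the series, read in an ADME assay on MRC5 cells (Homo sapiens) for cytotoxicity, read by resazurin assay, with a stated time of 7 days; on this read-out higher numbers stand for lower toxicity in this test and lower numbers for higher toxicity in this test: compound 1 `COc1cccc(NC(=O)Nc2ccc3nc(Oc4ccc(F)cc4C(C)O)c(Cc4ccccc4)cc3c2)c1` gives 64000 nM, compound 2 `COc1ccccc1NC(=S)Nc1ccc2nc(Oc3ccc(F)cc3C(C)O)c(Cc3ccccc3)cc2c1` gives 16000 nM and compound 3 `COc1ccc(NC(=S)Nc2ccc3nc(Oc4ccc(F)cc4C(C)O)c(Cc4ccccc4)cc3c2)cc1` gives 42300 nM. Compound 3 stands near the top of these three numbers, with a 1.5-fold lower number from compound 1 to compound 3 (0.18 log units; within the scatter) and a 2.6-fold higher number from compound 2 to compound 3 (0.42 log units; beyond the scatter). The next compound, compound 4 `COc1cccc(NC(=S)Nc2ccc3nc(Oc4ccc(F)cc4C(C)O)c(Cc4ccccc4)cc3c2)c1`, differs from compound 3 in one group: 3-methoxyphenyl in place of 4-methoxyphenyl on an amide-type nitrogen. The only measured move of the methoxy group is a 2.6-fold higher number from compound 2 to compound 3 (0.42 log units; beyond the scatter), and it starts from 2-methoxyphenyl, not from the group entering here. Compound 1 carries the entering 3-methoxyphenyl group with a carbonyl in place of the thiocarbonyl, and a 4.0-fold lower number from compound 1 to compound 2 (0.60 log units; beyond the scatter) shows that the two changes together can lower the number modestly. No shift beyond the scatter is expected in this assay, and the expected change is a 1.2-fold lower number from compound 3 to compound 4 (0.07 log units; within the scatter). Compound 4 is estimated at 36000 nM, with an expected range of 16000 nM to 75000 nM.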

Compound 4, half-maximal cytotoxic concentration: 64000 nM
Estimate against measurement, compound 4: 1.8-fold (0.25 log units) below, and the stated range covers the measured number.
By their numbers in this assay, from the lowest: compound 2; then compounds 3, 1 and 4 (each within the scatter of the next).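

In this assay the step of a 1.5-fold higher number from compound 3 to compound 4 (0.18 log units; within the scatter) leaves 3-methoxyphenyl and 4-methoxyphenyl level on the amide-type nitrogen, whereas a 4.0-fold higher number from compound 2 to compound 4 (0.60 log units; beyond the scatter) separates 3-methoxyphenyl from 2-methoxyphenyl. With 3-methoxyphenyl held fixed, thiocarbonyl for carbonyl gives no change at the digits printed from compound 1 to compound 4 (within the scatter) and so the lower number of compound 2 goes with 2-methoxyphenyl, not with the thiocarbonyl alone. Nothing at hand gives a reason for the 2-methoxyphenyl result.

Open, from the compounds shown here alone, is whether 2-methoxyphenyl lowers the number with a carbonyl as well. Also open, going by these compounds, is how a chlorophenyl or aminophenyl group would read on this nitrogen.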